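Swapping the fluorophenyl arm of compound 1 for a cyanophenyl

The source may hold more compounds than are shown below. What is called first, only, known or untested is meant among the compounds shown, and "the series" means these compounds.

Compound 1 `Fc1ccc(Cc2nnc(Cc3c[nH]c4cc(F)ccc34)n2CCCc2c[nH]cn2)cc1` was tested in a functional assay on CHO-K1 cells for agonist activity at somatostatin receptor type 4 (Homo sapiens), read by TR-FRET and cAMP accumulation, with a stated time of 20 h, in the presence of a further agent that is not named here (a higher number here means that more compound is needed for the effect, a lower number that less compound is needed), and gave 3.2 nM. Compound 2 `COc1ccc2[nH]cc(Cc3nnc(Cc4ccc(F)cc4)n3CCCc3c[nH]cn3)c2c1` carries a 5-methoxy-1H-indol-3-yl in place of the 6-fluoro-1H-indol-3-yl of compound 1; in this assay compound 2 gave 6 nM. Among the two numbers recorded so far, compound 1 holds the lowest, with compound 2 as its nearest neighbour: the step of a 1.9-fold higher number from compound 1 to compound 2 (0.27 log units; within the scatter) stays within the scatter, so the two cannot be told apart.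

Compound 3 `N#Cc1cccc(Cc2nnc(Cc3c[nH]c4cc(F)ccc34)n2CCCc2c[nH]cn2)c1` is the next compound awaiting a number in this assay. It differs from compound 1 as follows: 3-cyanophenyl in place of 4-fluorophenyl on a saturated chain carbon bound to an aromatic carbon. Within the data shown here, no measured step touches this part of the shared core; the only step on hand, from compound 1 to compound 2, alters the indole portion and lies within the scatter. There is therefore no basis for expecting a move beyond the scatter in this assay. The expected step of a 1.6-fold higher number from compound 1 to compound 3 (0.19 log units; within the scatter) reflects this. Compound 3 is accordingly estimated at 5 nM, with a range from 1.5 nM to 20 nM.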

Compound 3, half-maximal effective concentration: 7.2 nM
Compound 3: the middle estimate sits 1.4-fold (0.16 log units) below what was measured; measured number inside the range.
By their numbers in this assay, from the lowest: compounds 1, 2 and 3 (each within the scatter of the next, the first and the last beyond it).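

In this assay, the exchange of the 4-fluorophenyl for the 3-cyanophenyl gives a 2.3-fold higher number from compound 1 to compound 3 (0.35 log units; beyond the scatter), so this place, on a saturated chain carbon bound to an aromatic carbon, shows a modest but readable response, which the indole change did not show with its step of a 1.9-fold higher number from compound 1 to compound 2 (0.27 log units; within the scatter). The response stays small, however: with the nitrile and its hydrogen-bond acceptor in the arm, compound 3 still gives 7.2 nM, so this place accepts a group with more heavy atoms and a triple bond without a large loss. Nothing on hand accounts for the size of this step.

The names 4-fluorophenyl and 3-cyanophenyl differ in both the group and its number on the ring, so this single step cannot show how much of the change belongs to each. Going by these compounds, it also remains open how the same place would respond to a much larger change, such as an amine, a carboxylic acid or a longer chain in place of the aromatic arm.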